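This account rests on a few compounds, and the source may have more. Where it says the series, first, only, none or still open, it means among the compounds named here.

Measured compounds:
- compound 1, `CNC(=O)/C=C/c1ccncc1-c1ccc2ccccc2c1`: 101%
- compound 2, `CNC(=O)/C=C/c1ccncc1-c1ccc2cnn(C)c2c1`: 99%

Of the compounds shown here, two have been measured in an assay on a protein complex for inhibition of CDK8/Cyclin C (Homo sapiens), with a stated time of 1 h, tested at 10 uM; a higher number here means more inhibition at the concentration tested (going by the name of the read-out), a lower number less inhibition. Compound 1, whose structure is `CNC(=O)/C=C/c1ccncc1-c1ccc2ccccc2c1`, gives 101% in this assay. Compound 2, `CNC(=O)/C=C/c1ccncc1-c1ccc2cnn(C)c2c1`, gives 99%. The two numbers stand within the usual scatter of each other, so nothing separates compound 1 from compound 2 on this evidence; compound 1 is simply one of two compounds whose numbers in this assay stand level with each other.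

The step now followed leads from compound 1 to compound 3, `NC(=O)/C=C/c1ccncc1-c1ccc2ccccc2c1`. The change is a small one: hydrogen in place of methyl on an amide-type nitrogen. Going by the values given here, no step between two measured compounds has been recorded, so there is no measured precedent for hydrogen in place of methyl on an amide-type nitrogen here, and any expectation rests only on the level of compound 1 itself.

Given that compound 1 gives 101% and compound 2 sits with it, compound 3 is expected to show a number of about the same level in this assay, with a step of a number 9 percentage points lower from compound 1 to compound 3 (within the scatter) anticipated as little beyond the scatter. Compound 3 is estimated to give 92%, in a range from 70% to 101%.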

Compound 3, a percentage reported as inhibition, at one concentration (the size of the read-out at that concentration, not a potency): 102%
Estimate against measurement, compound 3: 10 percentage points below; measured number outside the range, above it.
By their numbers in this assay, from the lowest: compounds 2, 1 and 3 (each within the scatter of the next).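

Placing hydrogen in place of methyl on an amide-type nitrogen gives, in this assay, a number 1 percentage points higher from compound 1 to compound 3 (within the scatter) and so shows that this methyl is not required for the reading at the one concentration tested. The earlier compounds shown here differed only in the group on the other side of the core and said nothing about this position, which now has its first measured step. The read-out gives the size of inhibition at one concentration and not a potency, and it cannot tell whether compound 1 and compound 3 would differ at a lower concentration; nothing available accounts for the result at the level of cause.

The compounds shown leave open how a larger group on this nitrogen, such as ethyl, cyclopropyl or a longer chain ending in an amine, would read, and whether the amide itself could give way to a carboxylic acid or a nitrile. They also leave open whether the same change from methyl to hydrogen would read alike on the core of compound 2.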